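Swapping Bromo for Fluoro on an Aromatic Ring

The source may report more compounds than this note shows. Statements on the series, on what has been measured and on what is new or still open speak of the compounds shown alone.

- Compound 1 `COc1ccc(/C=C2\CCC/C(=C\c3cccc(OC)c3OC)C2=O)cc1`: 401000 nM
- Compound 2 `COc1cccc(/C=C2\CCC/C(=C\c3ccc(Br)cc3)C2=O)c1OC`: 31500 nM

Of the two compounds measured in an ADME assay on Vero cells (Chlorocebus sabaeus) for inhibition (a higher number here means that more compound is tolerated, a lower number that less compound is tolerated), compound 2 has the lower number, 31500 nM. Compound 3 `COc1cccc(/C=C2\CCC/C(=C\c3ccc(F)cc3)C2=O)c1OC` keeps the core of compound 2 and changes one group: fluoro in place of bromo on an aromatic carbon. Here, bromo leaves and fluoro enters. Going by the values given here, one measured step bears on this: a 13-fold lower number from compound 1 to compound 2 (1.10 log units; beyond the scatter). That large step, beyond the scatter, put bromo in place of methoxy on an aromatic carbon. Among the compounds with values here, no measured compound carries fluoro, so it is only a rough guide. Compound 1, which has no bromo, gives 401000 nM, so a small upward move is expected in this assay when bromo leaves. The expected change is a 1.9-fold higher number from compound 2 to compound 3 (0.28 log units; within the scatter), which may not clear the scatter. For compound 3 the estimated value is 60000 nM, with an expected range of 20000 nM to 200000 nM.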

Compound 3, half-maximal cytotoxic concentration: 33200 nM
Estimate against measurement, compound 3: 1.8-fold (0.26 log units) above, and the stated range covers the measured number.
By their numbers in this assay, from the lowest: compounds 2 and 3 (each within the scatter of the next); then compound 1.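

Going from 4-bromophenyl to 4-fluorophenyl gives a 1.1-fold higher number from compound 2 to compound 3 (0.02 log units; within the scatter) in this assay, so at this place on the ring the two halogens cannot be told apart. Fluoro in place of methoxy gives a 12-fold lower number from compound 1 to compound 3 (1.08 log units; beyond the scatter) and sits close to the earlier 13-fold lower number from compound 1 to compound 2 (1.10 log units; beyond the scatter) with bromo in place of methoxy, which shows that the large step is not particular to bromo and appears with either of these two halogens. Nothing available explains why the numbers fall this way.

Going by these compounds, whether the step belongs to halogens in general or simply to losing the methoxy group remains open, since both compounds with a lower number carry a halogen here. An amine, a carboxylic acid or a longer chain such as butoxy at the same place could help separate those two readings.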